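The source may report more compounds than this note shows. Statements on the series, on what has been measured and on what is new or still open speak of the compounds shown alone.

Measured so far:
compound 1 `O=[N+]([O-])c1cn2c(n1)OC[C@@H](NCc1ccc(OC(F)(F)F)cc1)C2` — 131 ug/mL
compound 2 `O=C(NCc1ccc(OC(F)(F)F)cc1)O[C@@H]1COc2nc([N+](=O)[O-])cn2C1` — 10 ug/mL

In a physicochemical assay for solubility, read by HPLC, measured as kinetic solubility, at pH 7 (a lower number here means a less soluble compound, a higher number a more soluble compound), compound 2 stands lowest of the two numbers; the gap to compound 1 lies beyond the usual scatter, so compound 2 is the less soluble of the pair. Compound 3 `O=C(NCc1ccc(-c2ccc(OC(F)(F)F)cc2)cc1)O[C@@H]1COc2nc([N+](=O)[O-])cn2C1` keeps the carbamate and core of compound 2 and differs only at one aromatic carbon: 4-(trifluoromethoxy)phenyl in place of trifluoromethoxy on an aromatic carbon. With a second aromatic ring entering and nothing polar added, a downward step in this assay beyond the scatter is expected, a 5.0-fold lower number from compound 2 to compound 3 (0.70 log units; beyond the scatter). Compound 3 is estimated at 2 ug/mL, in the range 0.5 ug/mL to 8 ug/mL.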

Compound 3, solubility: 0.34 ug/mL
Compound 3: middle estimate off by 5.9-fold (0.77 log units), on the high side; measured number below the stated range.
By their numbers in this assay, from the lowest: compound 3; then compound 2; then compound 1.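

In this assay, among these compounds, 4-(trifluoromethoxy)phenyl in place of trifluoromethoxy on an aromatic carbon gives a 29-fold lower number from compound 2 to compound 3 (1.47 log units; beyond the scatter) and is the first single-place step. With the carbamate and core unchanged, the number at this position responds strongly to the added six-membered aromatic ring of carbon only. No measurement at hand accounts for the size of this step.

Still open, going by these compounds, is how the number moves with an amine or a carboxylic acid on the added ring. Also open, on these data alone, is whether the same change gives a step of similar size on compound 1, which lacks the carbamate.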